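This account rests on a few compounds, and the source may have more. Where it says the series, first, only, none or still open, it means among the compounds named here.

Measured so far:
- compound 1, `COc1cc(/C=C2\CCC/C(=C\c3ccccc3Br)C2=O)cc(OC)c1OC`: 2800 nM
- compound 2, `COc1cc(/C=C2\CCC/C(=C\c3ccc(F)c(F)c3)C2=O)cc(OC)c1OC`: 1700 nM
- compound 3, `COc1cc(/C=C2\CCC/C(=C\c3ccc(O)c(O)c3)C2=O)cc(OC)c1OC`: 8500 nM

In a functional assay on HT-29 cells (Homo sapiens) for antiproliferative activity, read by MTT assay, with a stated time of 72 h (a lower number here means a stronger inhibitor, a higher number a weaker inhibitor), compound 3 gives the highest number of the three, a weaker inhibitor than compound 1 by a 3.0-fold higher number from compound 1 to compound 3 (0.48 log units; beyond the scatter) and than compound 2 by a 5.0-fold higher number from compound 2 to compound 3 (0.70 log units; beyond the scatter). Compound 4, `COc1cc(/C=C2\CCC/C(=C\c3ccc(O)c(Cl)c3)C2=O)cc(OC)c1OC`, differs from compound 3 by chloro in place of hydroxy on an aromatic carbon. Within the data shown here, no measured step swaps a hydroxy for a chloro, so the only guide is that the two compounds carrying halogens on that ring, compound 1 and compound 2, both give lower numbers than compound 3. A modest step toward a lower number is therefore expected for compound 4, estimated at a 2.1-fold lower number from compound 3 to compound 4 (0.33 log units; beyond the scatter). Compound 4 is expected to give 4000 nM, within 1500 nM to 11000 nM.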

Compound 4, half-maximal inhibitory concentration: 3400 nM
Compound 4: the middle estimate sits 1.2-fold (0.07 log units) above what was measured; the range from low to high includes it.
By their numbers in this assay, from the lowest: compounds 2, 1 and 4 (each within the scatter of the next); then compound 3.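

In this assay, chloro in place of one hydroxy gives a 2.5-fold lower number from compound 3 to compound 4 (0.40 log units; beyond the scatter) and so shows that a change at this one position can move the number beyond the scatter, whereas earlier steps replaced the whole ring. The remaining hydroxy does not set compound 4 apart from the rings carrying only halogens, with a 2.0-fold higher number from compound 2 to compound 4 (0.30 log units; within the scatter) and a 1.2-fold higher number from compound 1 to compound 4 (0.08 log units; within the scatter) as the two comparisons. Nothing available explains the step.

From the compounds shown here alone, what an amine or a methyl group would give at this position stays open, as does the part played by the remaining hydroxy group.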